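This account rests on a few compounds, and the source may have more. Where it says the series, first, only, none or still open, it means among the compounds named here.

Working notes on the series.

The shared core is a diacyl amidine carrying two thiophene carboxamide arms. Compound 3 `CS/C(=N\C(=O)c1cccs1)NC(=O)c1cccs1` carries methylsulfanyl on the central carbon, compound 2 `O=C(/N=C(/NC(=O)c1cccs1)[Se]Cc1ccccc1)c1cccs1` the selenium-linked benzyl group, and compound 1 `CS/C(=N\C(=O)c1csc([N+](=O)[O-])c1)NC(=O)c1csc([N+](=O)[O-])c1` pairs methylsulfanyl with nitrated thiophene arms. Compound 4 `O=C(/N=C(/NC(=O)c1csc([N+](=O)[O-])c1)[Se]Cc1ccccc1)c1csc([N+](=O)[O-])c1` combines the selenium-linked benzyl group with the nitrated arms and has not yet been measured.

In a functional assay on HepG2 cells (Homo sapiens) for cytotoxicity, read by MTT assay, with a stated time of 72 h (on this read-out higher numbers stand for weaker inhibition of growth and lower numbers for stronger inhibition of growth), compound 3 gives a value that is a limit of the assay, > 100000 nM. In this assay compound 2 gives 34700 nM and compound 1 gives 63400 nM; the values of compound 1 and compound 2 lie within the usual scatter of each other. How the cores of compound 1 and compound 3 differ is not broken down here.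

The change a group of 8 heavy atoms (7 carbon, 1 selenium; one six-membered aromatic ring of carbon only) in place of a group of 2 heavy atoms (1 carbon, 1 sulfur; no ring), on a carbon with a double bond to nitrogen gives an at least 2.8-fold lower number from compound 3 to compound 2 (0.45 log units; beyond the scatter). The step is reported only as a lower bound since compound 3 sits at the limit of > 100000 nM in this assay, at which 1 of the 3 values shown sits.

The same kind of change is made from compound 1 to compound 4, (a group of 8 heavy atoms (7 carbon, 1 selenium; one six-membered aromatic ring of carbon only) in place of a group of 2 heavy atoms (1 carbon, 1 sulfur; no ring), on a carbon with a double bond to nitrogen), with the place line matching word for word. On the basis of the step from compound 3 to compound 2, compound 4 is expected to show a 3.2-fold lower number from compound 1 to compound 4 (0.50 log units; beyond the scatter), with the wider spread reflecting that the measured step is itself only a bound. Compound 4 is therefore estimated at 20000 nM in this assay, expected between 7000 nM and 55000 nM.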

Compound 4, concentration for 50% growth inhibition: 34100 nM
Compound 4: the middle estimate sits 1.7-fold (0.23 log units) below what was measured; the measured number falls inside the stated range.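

In this assay, putting the selenium-linked benzyl group in place of methylsulfanyl on the core of compound 1 gives a 1.9-fold lower number from compound 1 to compound 4 (0.27 log units; within the scatter), so on this core the effect of the change cannot be told apart from the usual scatter. Carried over from the core of compound 3, the change therefore yields no step beyond the scatter on the second core, yet this does not show that the two cores respond differently: the same change on two cores in this assay, an at least 2.8-fold lower number (0.45 log units; beyond the scatter) from compound 3 to compound 2 and a 1.9-fold lower number (0.27 log units; within the scatter) from compound 1 to compound 4; the limit leaves it open whether they differ. The earlier step has only a bound for its size, as compound 3 sits at a limit of the assay, and two steps of this kind support no general rule for the series: the limit of > 100000 nM in this assay, at which 1 of the 4 values shown sits.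

The compounds shown leave open whether the step follows the selenium atom or the benzyl ring, and a benzylsulfanyl group or a methylselanyl group on the carbon with a double bond to nitrogen would separate the two. Also open, as far as these compounds go, is how an amine or a longer alkyl chain at that place would read out on either core, and whether any such group would give a step beyond the scatter on the core of compound 1.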